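Replacing 2-chlorophenyl with furan-2-yl on a carbonyl carbon

The source may report more compounds than this note shows. Statements on the series, on what has been measured and on what is new or still open speak of the compounds shown alone.

In a functional assay on MCF7 cells (Homo sapiens) for antiproliferative activity, read by MTT assay, with a stated time of 72 h (a lower number here means a stronger inhibitor, a higher number a weaker inhibitor), compound 1 (`CC1=CC[C@H]2[C@H](CC[C@]2(C)O)C(C)(C)[C@@H]1CC[C@H]1[C@]2(C)CC[C@H](OC(=O)NS(=O)(=O)c3ccc(C)cc3)C(C)(C)O[C@H]2CC[C@@]1(C)O`) gives > 50000 nM as a limit of the assay, not a number. Compound 2 (`CC1=CC[C@H]2[C@H](CC[C@]2(C)O)C(C)(C)[C@@H]1CC[C@H]1[C@]2(C)CC[C@H](OC(=O)c3ccc(F)cc3)C(C)(C)O[C@H]2CC[C@@]1(C)O`) gives 33500 nM and compound 3 (`CC1=CC[C@H]2[C@H](CC[C@]2(C)O)C(C)(C)[C@@H]1CC[C@H]1[C@]2(C)CC[C@H](OC(=O)c3ccccc3Cl)C(C)(C)O[C@H]2CC[C@@]1(C)O`) gives 12100 nM as the lowest number shown. Compound 4 (`CC1=CC[C@H]2[C@H](CC[C@]2(C)O)C(C)(C)[C@@H]1CC[C@H]1[C@]2(C)CC[C@H](OC(=O)c3ccco3)C(C)(C)O[C@H]2CC[C@@]1(C)O`) has furan-2-yl in place of 2-chlorophenyl on a carbonyl carbon. The closest guide is the modest step of a 2.8-fold lower number from compound 2 to compound 3 (0.44 log units; beyond the scatter) between two groups that each carry a ring. The step of an at least 4.1-fold lower number from compound 1 to compound 3 (0.61 log units; beyond the scatter) rests on a limit and guides less. Since compound 3 sits lowest at 12100 nM among the numbers, a modest rise is expected rather than a further fall. The expected change is a 2.1-fold higher number from compound 3 to compound 4 (0.32 log units; beyond the scatter) in this estimate. For compound 4 the estimated value is 25000 nM within an expected range of 10000 nM to 50000 nM in this assay.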

Compound 4, half-maximal inhibitory concentration: 25700 nM
Compound 4: middle estimate off by 1.0-fold (0.01 log units), on the low side; the range from low to high includes it.
By their numbers in this assay, from the lowest: compound 3; then compounds 4 and 2 (each within the scatter of the next). At a limit, above all of these: compound 1.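

In this assay, furan-2-yl does not match 2-chlorophenyl on this carbonyl carbon, giving a 2.1-fold higher number from compound 3 to compound 4 (0.33 log units; beyond the scatter); against 4-fluorophenyl it gives a 1.3-fold lower number from compound 2 to compound 4 (0.12 log units; within the scatter), so a five-membered aromatic ring can stand here in place of that six-membered one with no change beyond the scatter. The remaining step, an at least 1.9-fold lower number from compound 1 to compound 4 (0.28 log units; that floor lies within the scatter), is only a floor. Compound 1 stands at a limit, not a number: the limit of > 50000 nM in this assay, at which 1 of the 4 values shown sits.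

The compounds shown leave open whether this carbonyl carbon needs a ring at all, which an amine or a longer alkyl chain there would test. They also leave open what the chlorine of compound 3 adds, which plain phenyl would test.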